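From Methyl to Isopropyl at the Assay Limit

The source may hold more compounds than are shown below. What is called first, only, known or untested is meant among the compounds shown, and "the series" means these compounds.

Compound 1 (`O=C(NN1CCOC1=O)c1[nH]c2ccc(Cl)cc2c1S(=O)(=O)c1ccccc1`), compound 2 (`Cc1cc(C)cc(S(=O)(=O)c2c(C(=O)NN3CCOC3=O)[nH]c3ccc(Cl)cc23)c1`) and compound 3 (`CNNC(=O)c1[nH]c2ccc(Cl)cc2c1S(=O)(=O)c1cc(C)cc(C)c1`) were tested in a functional assay on cells (Lymphocyte, Homo sapiens) for cytotoxicity; a lower number here means that less compound is tolerated, a higher number that more compound is tolerated. Compound 1 gives > 100 uM, which is a limit of the assay. Compound 2 gives > 100 uM, again a limit. Compound 3 gives > 100 uM, also only a limit. The set therefore shows (the limit of > 100 uM in this assay, at which 3 of the 3 values shown sit).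

Compound 4 (`Cc1cc(C)cc(S(=O)(=O)c2c(C(=O)NNC(C)C)[nH]c3ccc(Cl)cc23)c1`) differs from compound 3 by isopropyl in place of methyl on an amine nitrogen. Among the compounds with values here, two measured steps bear on it, a step that the two limits leave unreadable from compound 1 to compound 2 and a step that the two limits leave unreadable from compound 2 to compound 3, so no step beyond the scatter can be expected in this assay on their evidence. The estimated outcome is a step that the limit leaves unreadable from compound 3 to compound 4. Compound 4 is expected at 120 uM, with an estimated range of 50 uM to 250 uM.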

Compound 4, half-maximal toxic concentration: > 100 uM
Compound 4: no number, only a limit; the forecaster's own chance of this, stated with the estimate: 75%; the middle value lies beyond the limit too.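

In this assay, within the data shown here, compound 4 gives > 100 uM, which is a limit, so no step from compound 2 or compound 3 to compound 4 can be read. The set stays as it was: the limit of > 100 uM in this assay, at which 4 of the 4 values shown sit. On these data alone, whether isopropyl in place of methyl on an amine nitrogen changes the tolerated concentration at all remains open.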